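The source may report more compounds than this note shows. Statements on the series, on what has been measured and on what is new or still open speak of the compounds shown alone.

Compound 1 (`O=C(NNc1ccc(F)cc1)c1ccccc1NS(=O)(=O)c1cnc(O)nc1O`) was tested in a functional assay on A549 cells (Homo sapiens) for antiproliferative activity, read by MTT assay, with a stated time of 24 h; a higher number here means a weaker inhibitor, a lower number a stronger inhibitor. In this assay compound 1 gives > 20000 nM, which is a limit of the assay and not a number. It therefore has no exact position on the scale. Compound 2 (`O=C(NNC(=O)c1ccc(NS(=O)(=O)c2cnc(O)nc2O)cc1)c1ccc(F)cc1`), which also carries a (4-fluorophenyl)carbonyl group, gives > 20000 nM, again a limit. Among the measured compounds shown here, the whole measured picture so far is the limit of > 20000 nM in this assay, at which 2 of the 2 values shown sit, so no measured step between two compounds is available as a guide.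

Compound 3 (`O=C(NNC(=O)c1ccccc1NS(=O)(=O)c1cnc(O)nc1O)c1ccc(F)cc1`) has not yet been measured. It is made from compound 1 by placing (4-fluorophenyl)carbonyl in place of 4-fluorophenyl on an amine nitrogen. For the measured compounds named here, the only hint comes from compound 2, whose > 20000 nM shows that this group alone does not guarantee a measurable result. No change beyond the usual scatter is expected in this assay, and the estimated step is a step that the limit leaves unreadable from compound 1 to compound 3. A limit may well be reported again. For compound 3 the expected value is 28000 nM, with an estimated range from 12000 nM to 60000 nM.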

Compound 3, half-maximal inhibitory concentration: > 20000 nM
Compound 3: a limit, no number; the forecaster's own chance of this, stated with the estimate: 75%; the middle value lies beyond the limit too.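

In this assay compound 3 gives > 20000 nM, which is a limit of the assay and not a number. Compound 1 also stands at a limit, so the step between compound 1 and compound 3 cannot be read. All the results shown remain at one limit: the limit of > 20000 nM in this assay, at which 3 of the 3 values shown sit.

The compounds shown leave open whether any change to the shared core would give a measurable value in this assay.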